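A few compounds are considered here, and "the series" means these few. Any claim that something is new, unique, unknown or untested is made for them only; others in the source may bear on it.

Of the compounds shown here, two have so far been tested in a functional assay on A549 cells (Homo sapiens) for cytotoxicity, read by MTT assay, with a stated time of 72 h; a lower number here means a stronger inhibitor, a higher number a weaker inhibitor. For compound 1 `O=C(Nc1ccc(Oc2ccnc3[nH]ccc23)c(F)c1)c1nn(-c2ccc(Br)cc2)ccc1=O` the result is a limit and not a number, > 60000 nM. Compound 2 `Cc1cc(=O)n(-c2cccc(F)c2)nc1C(=O)Nc1ccc(Oc2ncnc3[nH]ccc23)cc1` gives 34800 nM, the only actual number shown. The other reading, that of compound 1, is the limit of > 60000 nM in this assay, at which 1 of the 2 values shown sits. Compound 3 `Cc1cc(=O)n(-c2cccc(C(F)(F)F)c2)nc1C(=O)Nc1ccc(Oc2ncnc3[nH]ccc23)cc1` differs from compound 2 by trifluoromethyl in place of fluoro on an aromatic carbon. Within the data shown here, no measured step of this kind is available in the set. The expected change from compound 2 to compound 3 is a 1.4-fold lower number from compound 2 to compound 3 (0.14 log units; within the scatter), a small move at most. Compound 3 is therefore estimated at 25000 nM, within a range of 8000 nM to 60000 nM.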

Compound 3, half-maximal inhibitory concentration: 7570 nM
The estimate for compound 3 lay 3.3-fold (0.52 log units) above the measured number; the whole stated range lies above it.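

In this assay, the place on the aromatic ring meta to a large group responds to substitution: trifluoromethyl in place of fluoro gives a 4.6-fold lower number from compound 2 to compound 3 (0.66 log units; beyond the scatter). Among these compounds, this is the first measured step, and it shows that this single change, 3-fluorophenyl to 3-(trifluoromethyl)phenyl, moves the number beyond the scatter. Nothing measured here bears on the reason for this step.

As far as these compounds go, whether an amine, a methoxy group or a carboxylic acid at this place would move the number the same way remains open. So does whether the step carries over to the core of compound 1.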